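Compound 4 of a dilauroyl thioglycerol cysteine amide series

A few compounds are considered here, and "the series" means these few. Any claim that something is new, unique, unknown or untested is made for them only; others in the source may bear on it.

Measured so far:
compound 1 `CCCCCCCCCCCC(=O)OC[C@H](CSC[C@@H](N)C(=O)NC(C)(C)CO)OC(=O)CCCCCCCCCCC` 15500 nM
compound 2 `CCCCCCCCCCCC(=O)OC[C@H](CSC[C@@H](N)C(=O)NCCO)OC(=O)CCCCCCCCCCC` 24 nM
compound 3 `CCCCCCCCCCCC(=O)OC[C@H](CSC[C@@H](N)C(=O)NC1(CO)CC1)OC(=O)CCCCCCCCCCC` 265 nM

In an assay on HEK293 cells for agonist activity at Toll-like receptor 2 (Homo sapiens) (a lower number here means that less compound is needed, a higher number that more compound is needed for the effect), compound 3 stands second highest of the three numbers, with compound 2 below it by an 11-fold higher number from compound 2 to compound 3 (1.04 log units; beyond the scatter) and compound 1 above it by a 58-fold lower number from compound 1 to compound 3 (1.77 log units; beyond the scatter). Compound 4 `CCCCCCCCCCCC(=O)OC[C@H](CSC[C@@H](N)C(=O)NC(C)CCc1ccccc1)OC(=O)CCCCCCCCCCC` differs from compound 3 by 1-methyl-3-phenylpropyl in place of 1-(hydroxymethyl)cyclopropyl on an amide-type nitrogen. Every measured step keeps a hydroxymethyl on the amide substituent and varies only its carbon framework, yet those steps are large: a 650-fold lower number from compound 1 to compound 2 (2.81 log units; beyond the scatter), a 58-fold lower number from compound 1 to compound 3 (1.77 log units; beyond the scatter) and an 11-fold higher number from compound 2 to compound 3 (1.04 log units; beyond the scatter). Going by the values given here, no measured step removes the hydroxyl or adds an aromatic ring, so no step bears directly on the change to compound 4. All three measured steps at this nitrogen lie beyond the scatter. A step beyond the scatter is expected for compound 4 as well, and with the donor and acceptor both gone the direction is judged more likely upward. Compound 4 is therefore estimated at 1500 nM, within 100 nM to 20000 nM, an expected step of a 5.7-fold higher number from compound 3 to compound 4 (0.75 log units; beyond the scatter).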

Compound 4, half-maximal effective concentration: 160 nM
The estimate for compound 4 lay 9.4-fold (0.97 log units) above the measured number; the measured number falls inside the stated range.
By their numbers in this assay, from the lowest: compound 2; then compounds 4 and 3 (each within the scatter of the next); then compound 1.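

In this assay, going by these compounds alone, 1-methyl-3-phenylpropyl in place of 1-(hydroxymethyl)cyclopropyl on the amide-type nitrogen gives a 1.7-fold lower number from compound 3 to compound 4 (0.22 log units; within the scatter) and so shows that a number of this size at this position does not depend on a hydroxyl: the entering group has no hydrogen-bond donor or acceptor, and it brings a six-membered aromatic ring that no earlier compound had. The same group gives a 97-fold lower number from compound 1 to compound 4 (1.99 log units; beyond the scatter) but also a 6.7-fold higher number from compound 2 to compound 4 (0.82 log units; beyond the scatter), which leaves compound 2 with the lowest number of the four. Nothing measured here accounts for these steps. The compounds shown leave open whether the aromatic ring or the methyl of 1-methyl-3-phenylpropyl matters more, as a plain 3-phenylpropyl would begin to tell. They also leave open how a 2-aminoethyl or a carboxymethyl on this nitrogen would stand against the 2-hydroxyethyl of compound 2.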